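The compounds below may be only part of what the source reports. "The series", "measured", "known", "first", "only" and "open" are said of these compounds alone.

Of the compounds shown here, three have been tested in a functional assay on HO8910 cells (Homo sapiens) for inhibition, read by MTT assay, with a stated time of 24 h, tested at 0.1 ug/mL; a lower number here means less inhibition of growth, a higher number more inhibition of growth at the concentration tested. Compound 1 `O=C(CCCCC(S)CCS)NO` is reported as "not active" (no number reported), with no number attached. Compound 2 `O=C(CCCCC1CCSS1)Nc1ccccn1` gives 1.14%, and compound 3 `O=C(CCCCC(S)CCS)Nc1ccccc1` gives 7.37%. These two numbers lie within the usual scatter of each other, so compound 3 cannot be separated from compound 2 on this evidence, and there is no number from compound 1 to compare with either.

The next compound to be tested is compound 4 `O=C(CCCCC(S)CCS)Nc1ccccn1`. It differs from compound 3 by pyridin-2-yl in place of phenyl on an amide-type nitrogen. Going by the values given here, no pair of measured compounds shows this change on its own, so the data give no direct size for it. No step beyond the scatter is expected in this assay, in either direction. Among the compounds with values here, the only guide is that compound 4 shares the pyridin-2-yl on an amide-type nitrogen with compound 2, which gives 1.14%. The expected a number 2.4 percentage points lower from compound 3 to compound 4 (within the scatter) is therefore small and stays within the scatter. For compound 4 the estimated value is 5%, with an expected range of 0% to 14%.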

Compound 4, percent growth inhibition at one concentration: "not active" (no number reported)
Nothing numeric was reported for compound 4; the estimate stays without a comparison.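

Compound 3 gives 7.37% in this assay and compound 4 is recorded as "not active" (no number reported) here, so no step can be read between these two compounds. Nothing available bears on this result. The compounds shown leave open how far pyridin-2-yl in place of phenyl on an amide-type nitrogen shifts growth inhibition.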